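Swapping the indole for difluorophenyl on the amide

The compounds below may be only part of what the source reports. "The series", "measured", "known", "first", "only" and "open" are said of these compounds alone.

Compound 2 `O=C(c1cc2ccccc2[nH]1)N1CCC(NCCSC(c2ccc(F)cc2)c2ccc(F)cc2)CC1` gives 1130 nM in an assay on membranes from Cortex for displacement of a labelled ligand from Sigma non-opioid intracellular receptor 1 (Cavia porcellus), read by scintillation counting, with a stated time of 120 min (on this read-out lower numbers stand for stronger inhibition and higher numbers for weaker inhibition), the highest of the two numbers seen. The other, compound 1 `Fc1ccc(CN2CCC(NCCSC(c3ccc(F)cc3)c3ccc(F)cc3)CC2)cc1`, gives 13.3 nM; the step of an 85-fold higher number from compound 1 to compound 2 (1.93 log units; beyond the scatter) is large. Compound 3 `O=C(c1ccc(F)cc1F)N1CCC(NCCSC(c2ccc(F)cc2)c2ccc(F)cc2)CC1` carries 2,4-difluorophenyl in place of 1H-indol-2-yl on a carbonyl carbon. Among the measured compounds shown here, no measured step changes only the ring on the carbonyl; the step from compound 1 to compound 2 altered the whole group on the ring nitrogen, so it bears only loosely. Compound 3 is expected to stay near compound 2, with a 1.9-fold lower number from compound 2 to compound 3 (0.27 log units; within the scatter), giving an estimated 600 nM within 150 nM to 3000 nM.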

Compound 3, inhibition constant: 20.6 nM
The estimate for compound 3 lay 29-fold (1.46 log units) above the measured number, and the stated range ends above it.
By their numbers in this assay, from the lowest: compounds 1 and 3 (each within the scatter of the next); then compound 2.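

In this assay the ring on the carbonyl carbon decides the outcome, since 2,4-difluorophenyl in place of 1H-indol-2-yl gives a 55-fold lower number from compound 2 to compound 3 (1.74 log units; beyond the scatter) on an otherwise unchanged compound. The step of a 1.5-fold higher number from compound 1 to compound 3 (0.19 log units; within the scatter) shows that a carbonyl on the ring nitrogen is compatible with a number close to that of the 4-fluorobenzyl compound, so the carbonyl alone does not account for the weak result of compound 2. Nothing measured here explains why the two rings differ so much.

Still open, on these data alone, is whether a plain phenyl or a pyridine ring on the carbonyl carbon would match compound 3. As far as these compounds go, it is also open whether one fluorine on that ring would serve as well as two.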